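A few compounds are considered here, and "the series" means these few. Any claim that something is new, unique, unknown or untested is made for them only; others in the source may bear on it.

Measured so far: compound 1 `Cn1c(-c2ccc(NC(=O)CN3CCN(c4ccccc4)CC3)cc2)nc(-c2ccccc2)c1-c1ccccc1` with 63.7% in a functional assay on HT-29 cells (Homo sapiens) for cytotoxicity, read by MTT assay, with a stated time of 24 h, tested at 80 ug/mL (a lower number here means a weaker effect, a higher number a stronger effect of the compound at the concentration tested), and compound 2 `COc1ccc(CN2CCN(CC(=O)Nc3ccc(-c4nc(-c5ccccc5)c(-c5ccccc5)n4C)cc3)CC2)cc1` with 51.2% in this assay.

Compound 2 stands lowest of the two numbers; the step of a number 12.5 percentage points lower from compound 1 to compound 2 (beyond the scatter) separates it from compound 1. Compound 3 `Cn1c(-c2ccc(NC(=O)CN3CCN(Cc4ccc(Cl)cc4)CC3)cc2)nc(-c2ccccc2)c1-c1ccccc1` is not yet measured. It differs from compound 2 in one place: chloro in place of methoxy on an aromatic carbon. Going by the values given here, the only measured step, a number 12.5 percentage points lower from compound 1 to compound 2 (beyond the scatter), concerns a different change, the group on an amine nitrogen in a ring, and so does not bear directly on a chloro in place of a methoxy on the aromatic carbon; it only shows that a change at the outer end of this side chain can move the number modestly. Among the compounds with values here, with no step of the present kind on record, no shift beyond the scatter is expected, so the estimated step of a number 1.8 percentage points higher from compound 2 to compound 3 (within the scatter) is small. Compound 3 is therefore expected to give about 53%, within 40% to 66%.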

Compound 3, a percentage reported as activity, at one concentration (the size of the read-out at that concentration, not a potency): 60.7%
Compound 3: the middle estimate sits 7.7 percentage points below what was measured; the measured number falls inside the stated range.
By their numbers in this assay, from the lowest: compounds 2, 3 and 1 (each within the scatter of the next, the first and the last beyond it).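

In this assay, chloro in place of methoxy on this aromatic carbon gives a number 9.5 percentage points higher from compound 2 to compound 3 (within the scatter), so the two substituents cannot be told apart at this position. The 4-chlorobenzyl group in place of phenyl on the ring nitrogen gives a number 3 percentage points lower from compound 1 to compound 3 (within the scatter), whereas the earlier step from compound 1 to compound 2 lay beyond the scatter, so a substituted benzyl group at this nitrogen does not always separate from phenyl. No supporting data explain these readings.

Going by these compounds, it remains open whether an unsubstituted benzyl group, or a hydroxyl group or a carboxylic acid on the same aromatic carbon, would read like compound 2 or like compound 3. A single-concentration reading also leaves open how these compounds would compare across a range of concentrations.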